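The compounds below may be only part of what the source reports. "The series", "measured", "known", "first", "only" and "open" are said of these compounds alone.

Measured compounds:
compound 1 `O=[N+]([O-])C1=Cc2ccccc2OC1Nc1ccccc1[N+](=O)[O-]` — -0.26
compound 2 `O=[N+]([O-])C1=Cc2ccccc2OC1Nc1cccc([N+](=O)[O-])c1` — 2.47
compound 3 `COc1ccccc1NC1Oc2ccccc2C=C1[N+](=O)[O-]` — 2.52

In a physicochemical assay for acid dissociation, compound 1 gives -0.26, compound 3 gives 2.52 and compound 2 gives 2.47. Compound 2 and compound 3 lie within the scatter of each other. The change methoxy in place of nitro on an aromatic carbon gives a number 2.78 log units higher from compound 1 to compound 3 (beyond the scatter). Compound 1 and compound 2 share the same atoms joined differently; the difference between the two cores is not broken down here.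

Compound 4 `COc1cccc(NC2Oc3ccccc3C=C2[N+](=O)[O-])c1` is not yet measured. It differs from compound 2 by methoxy in place of nitro on an aromatic carbon, the same kind of change as in compound 1 to compound 3, but there the place was ortho to a large group, here meta to a large group. Within the data shown here, the step from compound 2 to compound 4 is expected to be a number 1.13 log units higher from compound 2 to compound 4 (beyond the scatter), smaller than a number 2.78 log units higher from compound 1 to compound 3 (beyond the scatter), which is the only comparable step and is taken as its ceiling. Compound 4 is estimated at 3.6, between 3 and 4.3.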

Compound 4, acid dissociation constant: 4.2
Compound 4: the middle estimate sits 0.60 log units below what was measured; the range from low to high includes it.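

In this assay, methoxy in place of nitro, here meta to a large group, gives a number 1.73 log units higher from compound 2 to compound 4 (beyond the scatter) and so moves the number the same way as the change on the other core, which gives a number 2.78 log units higher from compound 1 to compound 3 (beyond the scatter) at a different place. Across these two pairs the direction carries from one core to the other, but the size does not carry unchanged, as the new step is the smaller of the two. Two pairs set no rule for the series, and the change of place and of core cannot be separated here, with nothing at hand to account for the difference in size.

The compounds shown leave open how an amine or a carboxylic acid would read in place of the nitro on either core. From the compounds shown here alone, whether ethoxy or a longer chain follows methoxy also stays open.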